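The source may report more compounds than this note shows. Statements on the series, on what has been measured and on what is new or still open speak of the compounds shown alone.

Compound 1 `CCCSc1nc(N/N=C(\C)c2ccccc2O)c2nnn(Cc3ccc(Cl)cc3)c2n1` carries a chloro group on the benzyl ring of its core. In a functional assay on ECa-109 cells (Homo sapiens) for antiproliferative activity, read by MTT assay, with a stated time of 72 h (a higher number here means a weaker inhibitor, a lower number a stronger inhibitor), compound 1 gives 11200 nM. Two other compounds share that core but differ from compound 1 in several places at once, so no single change links them. Compound 3 `CCCSc1nc(N/N=C/c2cc(OC)c(OC)c(OC)c2)c2nnn(Cc3ccccc3)c2n1` gives 4060 nM in this assay, a lower number than compound 1 by a gap beyond the usual scatter, which leaves compound 1 with the highest of the two numbered values. Compound 2 `CCCSc1nc(N/N=C/c2cccs2)c2nnn(Cc3ccccc3)c2n1` does not yield a number at all but only (the limit of > 64000 nM in this assay, at which 1 of the 3 values shown sits). For compound 2 the reading in this assay is therefore the limit > 64000 nM.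

Compound 4 `CCCSc1nc(N/N=C(\C)c2ccccc2O)c2nnn(Cc3ccc(F)cc3)c2n1` differs from compound 1 in one place only: fluoro in place of chloro on an aromatic carbon. Among the measured compounds shown here, no pair of measured compounds here is separated by exactly this change, so no measured step shows what it does. The expectation is that a 1.3-fold higher number from compound 1 to compound 4 (0.10 log units; within the scatter) stays within the usual scatter. For compound 4 the expected value in this assay is 14000 nM, with a range from 6000 nM to 35000 nM.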

Compound 4, half-maximal inhibitory concentration: 21900 nM
Estimate against measurement, compound 4: 1.6-fold (0.19 log units) below, and the stated range covers the measured number.
By their numbers in this assay, from the lowest: compound 3; then compounds 1 and 4 (each within the scatter of the next). At a limit, above all of these: compound 2.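

In this assay, among the compounds shown here, the change from 4-chlorobenzyl to 4-fluorobenzyl gives a 2.0-fold higher number from compound 1 to compound 4 (0.29 log units; within the scatter) and is the first single change that can be read here, as the earlier compounds differ from one another in several places at once. At this position on the benzyl ring, the two halogens therefore cannot be told apart in this assay, and this one pair is all that supports that reading. Nothing measured here bears on what lies behind this result.

From the compounds shown here alone, it remains open whether a different group at this position, such as a methoxy group, an amine or a carboxylic acid, would shift the number beyond the scatter. Going by these compounds, it is also open whether fluoro and chloro would still match if the rest of the molecule carried a different side chain, such as a longer chain in place of the propylthio group.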